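Three Aryltriazenes Tested for Cytotoxicity in MT4 Cells

A few compounds are considered here, and "the series" means these few. Any claim that something is new, unique, unknown or untested is made for them only; others in the source may bear on it.

Compound 1, `Clc1cccc(/N=N/N2CCCC2)c1`, in an ADME assay on MT4 cells (Homo sapiens) for cytotoxicity, read by MTT assay, with a stated time of 96 h (on this read-out lower numbers stand for higher toxicity in this test and higher numbers for lower toxicity in this test), gives > 100000 nM, a limit of the assay.
Compound 2, `c1ccc(/N=N/N2CCCCC2)cc1`, in this assay gives > 100000 nM, a limit of the assay.
Compound 3, `c1ccc(/N=N/N2CCCC2)cc1`, in this assay gives > 100000 nM, a limit of the assay.

All three values sit at the same limit, (the limit of > 100000 nM in this assay, at which 3 of the 3 values shown sit), so none of them is a number. From compound 3 to compound 1 the change is chloro in place of hydrogen on an aromatic carbon, and the step that the two limits leave unreadable from compound 3 to compound 1 cannot be read because both values are limits. The difference between the cores of compound 2 and compound 3 is not broken down here.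

Compound 4, `Clc1ccc(/N=N/N2CCCCC2)cc1`, is not yet measured. From compound 2 it differs by chloro in place of hydrogen on an aromatic carbon. This is the same kind of change as from compound 3 to compound 1, but the place differs: here the chloro stands para to a group of 8 heavy atoms, there meta to a group of 7 heavy atoms. Since compound 1, compound 2 and compound 3 all rest at the limit (the limit of > 100000 nM in this assay, at which 3 of the 3 values shown sit), compound 4 is expected to stay there too, an estimated step that the limit leaves unreadable from compound 2 to compound 4. Compound 4 is therefore estimated at 150000 nM, between 60000 nM and 400000 nM.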

Compound 4, half-maximal cytotoxic concentration: > 100000 nM
Compound 4 was reported as a limit; the forecaster's own chance of this, stated with the estimate: 85%; the middle value is on the limit's open side.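

In this assay compound 4 gives > 100000 nM as a limit of the assay and not a number, so the step from compound 2 to compound 4 cannot be read, and all four compounds stand at one limit: the limit of > 100000 nM in this assay, at which 4 of the 4 values shown sit. The compounds shown leave open how far apart their toxicities in this assay lie, and whether chloro in place of hydrogen on an aromatic carbon changes them at all.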